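Series notes: aryl swap on the saturated ring carbon

The compounds below may be only part of what the source reports. "The series", "measured", "known", "first", "only" and "open" are said of these compounds alone.

Measured so far:
compound 1 `CC1=C(C(=O)NCCCN2CCC(c3ccccc3C#N)CC2)[C@@H](c2ccc(F)c(F)c2)NC(=O)N1` — 0.25 nM
compound 2 `COCC1=C(C(=O)NCCCN2CCC(c3ccccc3C#N)CC2)[C@@H](c2ccc(F)c(F)c2)NC(=O)N1` — 0.42 nM

In an assay on CHO cells with Alpha-1A adrenergic receptor (Homo sapiens) as the target (on this read-out lower numbers stand for stronger inhibition and higher numbers for weaker inhibition), compound 2 gives the higher of the two numbers on hand; its nearest neighbour is compound 1, and the step of a 1.7-fold higher number from compound 1 to compound 2 (0.23 log units; within the scatter) lies within the scatter, so the two are not separated by this read-out. Compound 3 `COCC1=C(C(=O)NCCCN2CCC(c3ccccn3)CC2)[C@@H](c2ccc(F)c(F)c2)NC(=O)N1` carries pyridin-2-yl in place of 2-cyanophenyl on a saturated ring carbon. Among the compounds with values here, no measured pair differs at this place: the one recorded step concerns the methoxy on the saturated chain carbon and leaves the group on the saturated ring carbon untouched, so it does not bear on the change. As far as these compounds go, the exchange of 2-cyanophenyl for pyridin-2-yl is untested, and the expectation rests on compound 2 at 0.42 nM alone. A modest loss is expected, a 3.6-fold higher number from compound 2 to compound 3 (0.55 log units; beyond the scatter), with a wide range around it. Compound 3 is estimated at 1.5 nM, between 0.3 nM and 8 nM.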

Compound 3, inhibition constant: 0.45 nM
Compound 3: middle estimate off by 3.3-fold (0.52 log units), on the high side, within the range that was stated.
By their numbers in this assay, from the lowest: compounds 1, 2 and 3 (each within the scatter of the next).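

In this assay, the exchange of 2-cyanophenyl for pyridin-2-yl on the saturated ring carbon gives a 1.1-fold higher number from compound 2 to compound 3 (0.03 log units; within the scatter), so the read-out does not separate the two groups at this place. The first change tested here on the saturated ring carbon therefore shows that the nitrile and the carbon-only aromatic ring are not needed to keep a value of this order, even with the group going from 8 heavy atoms to 6. The data shown offer no explanation for this result.

As far as these compounds go, whether an unsubstituted phenyl, a pyridin-3-yl or a pyridin-4-yl group would give a comparable value on the saturated ring carbon remains open. Also open, from the compounds shown here alone, is whether pyridin-2-yl behaves the same way on the core of compound 1, which has hydrogen in place of the methoxy.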